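A Linked Methylpyrazole in Place of a Bare Pyrazole

This account rests on a few compounds, and the source may have more. Where it says the series, first, only, none or still open, it means among the compounds named here.

Compound 2 `N#Cc1cccc(-c2c[nH]c3ncc(-c4cn[nH]c4)cc23)c1` was measured in a physicochemical assay for solubility, read by LC-MS, in phosphate buffer, measured as thermodynamic solubility, with a stated time of 24 h, at pH 7.4 (on this read-out lower numbers stand for lower solubility and higher numbers for higher solubility), and gave 26000 nM. For the measured compounds named here, that is the lower of the two numbers measured so far: compound 1 `Cn1cc(-c2cnc3[nH]cc(-c4ccncc4)c3c2)cn1` gave 59000 nM in this assay, a gap that lies beyond the usual scatter. Compound 3 `Cn1cc(Nc2cnc3[nH]cc(-c4cccc(C#N)c4)c3c2)cn1` has not yet been measured. It differs from compound 2 in one place: (1-methyl-1H-pyrazol-4-yl)amino in place of 1H-pyrazol-4-yl on an aromatic carbon. Going by the values given here, no measured pair shows a step of this kind, so the expected step is small, a 1.2-fold higher number from compound 2 to compound 3 (0.06 log units; within the scatter), in neither direction clearly beyond the scatter. Compound 3 is therefore estimated at 30000 nM, with a range from 10000 nM to 90000 nM.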

Compound 3, solubility: 31000 nM
Compound 3: middle estimate off by 1.0-fold (0.01 log units), on the low side, within the range that was stated.
By their numbers in this assay, from the lowest: compounds 2, 3 and 1 (each within the scatter of the next, the first and the last beyond it).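

At this aromatic carbon, (1-methyl-1H-pyrazol-4-yl)amino in place of 1H-pyrazol-4-yl gives a 1.2-fold higher number from compound 2 to compound 3 (0.08 log units; within the scatter) in this assay. This first step at the position shows that the entering group, with its amino link and methyl, leaves the number within the scatter of compound 2. No measurement shown offers an explanation for this result. The compounds shown leave open how the amino link and the methyl would each read alone, since they enter together. They also leave open whether a morpholine or a carboxylic acid here would give a step beyond the scatter.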